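The source may hold more compounds than are shown below. What is called first, only, known or untested is meant among the compounds shown, and "the series" means these compounds.

Measured compounds:
compound 1 `CC(C)=CC[C@@H](OC(=O)CCO)C1=CC(=O)c2c(O)ccc(O)c2C1=O` – 67600 nM
compound 2 `CC(=O)OCCC(=O)O[C@H](CC=C(C)C)C1=CC(=O)c2c(O)ccc(O)c2C1=O` – 17300 nM
compound 3 `COCCO[C@H](CC=C(C)C)C1=CC(=O)c2c(O)ccc(O)c2C1=O` – 62400 nM

All three share the same core and differ only in the group carried on an oxygen on a saturated carbon. In a functional assay on HeLa cells (Homo sapiens) for cytotoxicity, read by MTT assay (a lower number here means a stronger inhibitor, a higher number a weaker inhibitor), compound 3 gives 62400 nM, the second highest of the three numbers: compound 1 sits nearest to it (a 1.1-fold lower number from compound 1 to compound 3 (0.03 log units; within the scatter)), compound 2 furthest (a 3.6-fold higher number from compound 2 to compound 3 (0.56 log units; beyond the scatter)).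

Compound 4 `CC(C)=CC[C@@H](OC(=O)C1CCOC1)C1=CC(=O)c2c(O)ccc(O)c2C1=O` has not been measured. Its difference from compound 3: (oxolan-3-yl)carbonyl in place of 2-methoxyethyl on an oxygen on a saturated carbon. The change thus exchanges the ether for an ester, the reverse of the type of step seen in a 3.6-fold higher number from compound 2 to compound 3 (0.56 log units; beyond the scatter), whereas the ester of compound 1, which carries a free hydroxyl, lies within the scatter of compound 3 (a 1.1-fold lower number from compound 1 to compound 3 (0.03 log units; within the scatter)). The new ester carries no hydroxyl, so it is expected to read closer to compound 2 than to compound 1, and a modestly lower number in this assay is expected, though the two ester cases disagree enough that the step could also stay within the scatter.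

For compound 4 the estimate is 30000 nM (range 12000 nM to 80000 nM), which means an expected step of a 2.1-fold lower number from compound 3 to compound 4 (0.32 log units; beyond the scatter).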

Compound 4, half-maximal inhibitory concentration: 73500 nM
The estimate for compound 4 lay 2.5-fold (0.39 log units) below the measured number, within the range that was stated.
By their numbers in this assay, from the lowest: compound 2; then compounds 3, 1 and 4 (each within the scatter of the next).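

In this assay, (oxolan-3-yl)carbonyl in place of 2-methoxyethyl on this oxygen leaves the reading within the scatter (a 1.2-fold higher number from compound 3 to compound 4 (0.07 log units; within the scatter)), so at this position an ester link does not by itself separate a compound from the ether, with compound 2 the one ester that goes against this. The ring-bearing ester stands clearly apart from the ester carrying 2-acetoxyethyl on the carbonyl carbon (a 4.2-fold higher number from compound 2 to compound 4 (0.63 log units; beyond the scatter)) but not from the ester carrying 2-hydroxyethyl there (a 1.1-fold higher number from compound 1 to compound 4 (0.04 log units; within the scatter)), which leaves compounds 1, 3 and 4 as one group and compound 2 alone at the lower number, a separation that rests on that single compound. Nothing shown here gives a reason for the separate place of compound 2.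

From the compounds shown here alone, whether the lower number needs the acetyl ending of the 2-acetoxyethyl group, or would also appear with a longer chain such as 3-acetoxypropyl on the carbonyl carbon, remains open. Also open, going by these compounds, is whether an amine or a carboxylic acid at the end of that chain would read with compound 2 or with the other three.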